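From compound 2 to compound 3: exchanging the outer ring

A few compounds are considered here, and "the series" means these few. Any claim that something is new, unique, unknown or untested is made for them only; others in the source may bear on it.

Compound 1, `CCCCCCCCCCCOc1ccccc1CCC(=O)OCCCOP(=O)(O)OC[C@H](N)C(=O)O`: 0.04
Compound 2, `N[C@@H](COP(=O)(O)OCCCOC(=O)CCc1ccccc1OCc1cccc(Oc2ccccc2Cl)c1)C(=O)O`: 0.069

Of the compounds shown here, two have been measured in an assay on cells for activation of probable G-protein coupled receptor 34 (Mus musculus), with a stated time of 1 h; a higher number here means a larger maximal response, a lower number a smaller maximal response. Compound 1 gives 0.04, and compound 2 gives 0.069. Compound 2 holds the higher of the two numbers, but its gap to compound 1 lies within the usual scatter, so the two cannot be told apart on these data. Compound 3 `N#Cc1ccc(Oc2cccc(COc3ccccc3CCC(=O)OCCCOP(=O)(O)OC[C@H](N)C(=O)O)c2)cc1` has not yet been measured. It differs from compound 2 in one place: 4-cyanophenyl in place of 2-chlorophenyl on an oxygen on an aromatic ring. Going by the values given here, no step between measured compounds is available, so nothing here shows how an exchange of this kind moves the maximal response. With both measured values low and indistinguishable, the step from compound 2 to compound 3 is expected to be small, in either direction, and not beyond the scatter. Compound 3 is therefore estimated at 0.08, with a range from 0.02 to 0.2, an expected step of a number 0.011 higher from compound 2 to compound 3 (within the scatter).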

Compound 3, intrinsic activity: the largest response reached, as a fraction of the reference agonist's: 0.041
Beside the measured number, compound 3's estimate is 0.039 above it; low and high end bracket the measured number.
By their numbers in this assay, from the lowest: compounds 1, 3 and 2 (each within the scatter of the next).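

In this assay, 4-cyanophenyl in place of 2-chlorophenyl on an oxygen on an aromatic ring gives a step of a number 0.028 lower from compound 2 to compound 3 (within the scatter). Going by these compounds alone, this is the first step between measured compounds that differ in one place, and it shows that this exchange, which brings in a triple bond and a hydrogen-bond acceptor, does not move the maximal response beyond the scatter. No measurement shown bears on the reason for this outcome.

The compounds shown leave open whether 4-chlorophenyl, which would keep the chlorine and change only where it sits on the ring, would behave the same way at this position. They also leave open whether a phenyl ring carrying an amine or a carboxylic acid could move the maximal response beyond the scatter.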